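The compounds below may be only part of what the source reports. "The series", "measured", "known", "first", "only" and "open" are said of these compounds alone.

Of the compounds shown here, two have so far been tested in a functional assay on aorta (Rattus norvegicus, strain Wistar) for inhibition, with a stated time of 30 min; on this read-out higher numbers stand for an effect only at larger amounts of compound and lower numbers for an effect already at smaller amounts. Compound 1 `CC(=O)Oc1ccccc1C(=O)OCOC(=O)c1cccc(OCCCO[N+](=O)[O-])c1` gives 140 nM in this assay. Compound 2 `CC(=O)Oc1ccccc1C(=O)OCOC(=O)c1ccc(S(=O)(=O)CCCO[N+](=O)[O-])cc1` gives 360 nM in this assay, the higher of the two numbers, and its gap to compound 1 lies beyond the usual scatter of repeated measurements. The next compound keeps the shared core of compound 2 and alters only the group on an aromatic carbon, giving compound 3 `CC(=O)Oc1ccccc1C(=O)OCOC(=O)c1ccc(CCCO[N+](=O)[O-])cc1`. The change is 3-(nitrooxy)propyl in place of (3-(nitrooxy)propyl)sulfonyl on an aromatic carbon. Within the data shown here, no step between two measured compounds of this kind is available, so the expectation rests on the two numbers alone and on the change itself. The expected step in this assay is modest and downward, a 1.4-fold lower number from compound 2 to compound 3 (0.16 log units; within the scatter), and may well remain inside the scatter. Compound 3 is accordingly estimated at 250 nM in this assay, within a range from 80 nM to 800 nM.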

Compound 3, half-maximal effective concentration in the aorta assay: 75 nM
Compound 3: the middle estimate sits 3.3-fold (0.52 log units) above what was measured; the measured number lies below the stated range.
By their numbers in the aorta assay, from the lowest: compounds 3 and 1 (each within the scatter of the next); then compound 2.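

Taking the sulfonyl out of the chain at this position gives, in the aorta assay, a 4.8-fold lower number from compound 2 to compound 3 (0.68 log units; beyond the scatter), the first direct reading of this change, since compounds 1 and 2 differ in more than one place. In a physicochemical assay for metabolic stability, read by HPLC, in phosphate buffer, with a stated time of 3 h, at pH 7.4, tested at 0.5 mM (a higher number here means that more of the compound is left, a lower number that less of the compound is left), compound 2 gives 70% and compound 3 gives 100%. The same change therefore goes with a lower number in the aorta assay and with more compound left intact in the physicochemical assay: the measured percent of the compound remaining of compound 2, 70%, and of compound 3, 100%, a number 30 percentage points higher (beyond the scatter)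

Whether the lower number in the aorta assay is linked to the compound staying intact cannot be told from this single pair. Also open, from the compounds shown here alone, is how other groups would behave on this aromatic carbon, such as a longer nitrooxy chain, an amine or a carboxylic acid.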